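From Ethoxy to Bromo: One Swap, One Open Question

The source may report more compounds than this note shows. Statements on the series, on what has been measured and on what is new or still open speak of the compounds shown alone.

Measured so far in a functional assay for inhibition, with Homo sapiens as the target; on this read-out lower numbers stand for stronger inhibition and higher numbers for weaker inhibition:
Compound 1 `COc1cc(OC)c(C(=O)/C=C/c2ccncc2)c(OC)c1`: 592 nM
Compound 2 `COc1cc(OC)c(C(=O)/C=C/c2ccc(C(N)=O)cc2)c(OC)c1`: 1790 nM
Compound 3 `CCOc1ccccc1C(=O)/C=C/c1ccccc1`: 609 nM

Repeat measurements of this kind never agree exactly, so small gaps between values carry no meaning. Compound 3 stands level with compound 1, within that scatter. Compound 2 lies higher than compound 3, beyond the scatter, which means weaker inhibition.

The next compound to be tested is compound 4 `O=C(/C=C/c1ccccc1)c1ccccc1Br`. It differs from compound 3 in one place: bromo in place of ethoxy on an aromatic carbon, ortho to a large group (bromo in place of ethoxy on an aromatic carbon).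

Among the compounds with values here, no two measured compounds differ in only one place, so the data give no direct guide to the effect of this swap. The expectation rests mainly on compound 3 at 609 nM, which shares everything with compound 4 except this one group. A small upward move is expected, a 1.1-fold higher number from compound 3 to compound 4 (0.06 log units; within the scatter), which would stay within the scatter and so would not count as a real change. For compound 4 the estimated value is 700 nM, with an expected range from 220 nM to 2200 nM.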

Compound 4, half-maximal inhibitory concentration: 1660 nM
The estimate for compound 4 lay 2.4-fold (0.38 log units) below the measured number; measured number inside the range.
By their numbers in this assay, from the lowest: compounds 1 and 3 (each within the scatter of the next); then compounds 4 and 2 (each within the scatter of the next).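

In this assay, within the data shown here, this is the first pair of compounds that differ in one place only, so it gives the first direct reading of a single change. Putting bromo in place of ethoxy on an aromatic carbon, ortho to a large group, brings a 2.7-fold higher number from compound 3 to compound 4 (0.44 log units; beyond the scatter), a modest step but one beyond the scatter, so the group in this place does affect the read-out and the higher number means weaker inhibition. The swap changes several things at once, since 3 heavy atoms with 1 hydrogen-bond acceptor leave and 1 heavy atom with 0 hydrogen-bond acceptors enters, and nothing measured here bears on which of these differences matters.

Still open, as far as these compounds go, is whether the oxygen, the length of the chain or the bromine itself carries the difference, and a methoxy group, a chloro group or a longer chain such as propoxy in this same place would help to separate these. Also open, from the compounds shown here alone, is whether this swap would give a step of similar size on a different core, such as the core of compound 1.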